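Cyclopentyl for Butyl on the Shared Core

This account rests on a few compounds, and the source may have more. Where it says the series, first, only, none or still open, it means among the compounds named here.

Of the compounds shown here, three have been tested in a functional assay on NCI-H460 cells (Homo sapiens) for antiproliferative activity, read by CCK-8 assay, with a stated time of 72 h, tested at 8 uM; on this read-out higher numbers stand for a stronger effect at the one concentration tested and lower numbers for a weaker effect. Compound 1 `CCCCn1cnc2c(Nc3ccccc3)nc(NCOCc3ccc(/C=C/C(=O)Nc4ccccc4N)cc3)nc21` gives 34.2%, the lowest of the three numbers. Compound 2 `Cc1ccc(Nc2nc(Cl)nc3c2ncn3Cc2ccc(/C=C/C(=O)Nc3ccccc3N)cc2)cc1` gives 51.3%, and compound 3 `CCCCn1cnc2c(Nc3cccc(Cl)c3)nc(NCOCc3ccc(/C=C/C(=O)Nc4ccccc4N)cc3)nc21` gives 51.1%. Within the data shown here, the one step that can be read directly is a number 16.9 percentage points higher from compound 1 to compound 3 (beyond the scatter), a change on an aromatic carbon of the aniline part of the shared core.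

Compound 4 `Nc1ccccc1NC(=O)/C=C/c1ccc(COCNc2nc(Nc3ccccc3)c3ncn(C4CCCC4)c3n2)cc1` differs from compound 1 in another place: cyclopentyl in place of butyl on an aromatic nitrogen. Among the measured compounds shown here, no measured pair here changes the group on that ring nitrogen, so the step from compound 1 to compound 3 does not bear on it directly; it only shows that a small change to compound 1 can move the number by a modest amount. With no guide for this particular change, the expectation is a step that stays within the scatter, in no firm direction: a number 3.8 percentage points higher from compound 1 to compound 4 (within the scatter). Compound 4 is therefore estimated at 38%, in a range from 25% to 52%.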

Compound 4, a percentage reported as inhibition, at one concentration (the size of the read-out at that concentration, not a potency): 59.7%
Compound 4: middle estimate off by 21.7 percentage points, on the low side; measured number above the stated range.
By their numbers in this assay, from the lowest: compound 1; then compounds 3, 2 and 4 (each within the scatter of the next).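

On the shared core, the group on the aromatic nitrogen matters: in this assay, cyclopentyl in place of butyl gives a number 25.5 percentage points higher from compound 1 to compound 4 (beyond the scatter). This is a second place where one change moves the number beyond the scatter, after the chloro on the aniline part in a number 16.9 percentage points higher from compound 1 to compound 3 (beyond the scatter). Nothing measured on these compounds accounts for the new step, so it stands as an observation without an explanation.

Groups such as cyclopropyl, cyclohexyl, isopropyl or a longer chain like hexyl on that nitrogen could help show whether the closed ring or the size of the group goes with the higher number. Going by these compounds, it also remains open whether cyclopentyl and chloro together would give a higher number than either alone, and the read-out at one concentration says nothing about potency.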